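Ethyl in place of butoxycarbonyl: cytotoxicity notes

A few compounds are considered here, and "the series" means these few. Any claim that something is new, unique, unknown or untested is made for them only; others in the source may bear on it.

Compound 1 `C=C1C(=O)OC[C@H]1CCOC(=O)Nc1ccc(C(=O)OCCCC)cc1` in an ADME assay on RAW264.7 cells (Mus musculus) for cytotoxicity, read by MTT assay, with a stated time of 18 h (a lower number here means that less compound is tolerated, a higher number that more compound is tolerated), gives 8940 nM, the lower of the two numbers shown, with the other within the scatter. Compound 2 `C=C1C(=O)OC[C@@H]1CCOC(=O)Nc1ccc(C(=O)OCCCC)cc1` in this assay gives 12700 nM; the step of a 1.4-fold higher number from compound 1 to compound 2 (0.15 log units; within the scatter) rests only on (the fact that compounds 1 and 2 differ only in the configuration as drawn). Compound 3 `C=C1C(=O)OC[C@H]1CCOC(=O)Nc1ccc(CC)cc1` carries ethyl in place of butoxycarbonyl on an aromatic carbon. For the measured compounds named here, no measured step touches this aryl substituent, and the only step measured was within the scatter, so no step beyond the scatter is expected in this assay. Compound 3 is estimated at 10000 nM, between 4000 nM and 25000 nM. The step of a 1.1-fold higher number from compound 1 to compound 3 (0.05 log units; within the scatter) is the expected change.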

Compound 3, half-maximal cytotoxic concentration: 11400 nM
For compound 3 the middle estimate is 1.1-fold (0.06 log units) below the measured one; the range from low to high includes it.
By their numbers in this assay, from the lowest: compounds 1, 3 and 2 (each within the scatter of the next).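

In this assay the aryl substituent now has a measured step of its own: ethyl in place of butoxycarbonyl on an aromatic carbon gives a 1.3-fold higher number from compound 1 to compound 3 (0.11 log units; within the scatter) for the exchange of a group of 7 heavy atoms and 2 hydrogen-bond acceptors for one of 2 heavy atoms and 0 hydrogen-bond acceptors. The earlier pair spoke only to configuration; this pair speaks to the group at this place, and even so large a change of group stays within the scatter. Open, on these data alone, is whether an amine, a carboxylic acid or a longer chain on this aromatic carbon would also stay within the scatter. Nothing at hand gives a reason for this step.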